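Swapping the Chloro and Trifluoromethyl Positions on a Urea Phenyl

The source may hold more compounds than are shown below. What is called first, only, known or untested is meant among the compounds shown, and "the series" means these compounds.

Measured so far:
Compound 1, `CC(C)(C)OC(=O)N1CCN(C(=O)Nc2ccc([N+](=O)[O-])cc2)C(c2ccccc2)C1`, gives 161000 nM in an ADME assay on A549 cells (Homo sapiens) for cytotoxicity, read by resazurin assay, with a stated time of 48 h; a higher number here means that more compound is tolerated, a lower number that less compound is tolerated.
Compound 2, `CC(C)(C)OC(=O)N1CCN(C(=O)Nc2cc(C(F)(F)F)ccc2Cl)C(c2ccccc2)C1`, gives 93400 nM in this assay.

Both compounds share the same core and differ only in the aryl group on the urea nitrogen. Among the compounds with values here, the step of a 1.7-fold lower number from compound 1 to compound 2 (0.24 log units; within the scatter) is the only measured step, and it lies within the scatter, so compound 2 stands within the scatter of compound 1, the sole other compound measured.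

Compound 3, `CC(C)(C)OC(=O)N1CCN(C(=O)Nc2ccc(Cl)c(C(F)(F)F)c2)C(c2ccccc2)C1`, has not yet been measured. Its change from compound 2 is 4-chloro-3-(trifluoromethyl)phenyl in place of 2-chloro-5-(trifluoromethyl)phenyl on an amide-type nitrogen: the same atoms joined differently, with no change in donors, acceptors or charge. Within the data shown here, no measured step mirrors such a rearrangement; the one step available, from a nitrophenyl to a chloro-trifluoromethylphenyl, stayed within the scatter. The expectation is therefore no change beyond the scatter, a 1.1-fold higher number from compound 2 to compound 3 (0.03 log units; within the scatter). Compound 3 is estimated at 100000 nM in this assay, with a range from 40000 nM to 250000 nM.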

Compound 3, half-maximal cytotoxic concentration: 27500 nM
Beside the measured number, compound 3's estimate is 3.6-fold (0.56 log units) above it; measured number below the stated range.
By their numbers in this assay, from the lowest: compound 3; then compounds 2 and 1 (each within the scatter of the next).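

In this assay, rearranging the groups on the urea phenyl gives a 3.4-fold lower number from compound 2 to compound 3 (0.53 log units; beyond the scatter) even though 2-chloro-5-(trifluoromethyl)phenyl and 4-chloro-3-(trifluoromethyl)phenyl hold the same atoms, so at this place on the urea nitrogen the arrangement of the chloro and trifluoromethyl groups matters, not only which groups are present. The 4-chloro-3-(trifluoromethyl)phenyl group also separates from 4-nitrophenyl, with a 5.9-fold lower number from compound 1 to compound 3 (0.77 log units; beyond the scatter) as the step, something 2-chloro-5-(trifluoromethyl)phenyl did not do. No measurement at hand accounts for this difference.

Whether the 4-chloro-3-(trifluoromethyl)phenyl result needs both groups remains open, as neither a plain 4-chlorophenyl nor a plain 3-(trifluoromethyl)phenyl is among the compounds shown. From the compounds shown here alone, it is also open how a phenyl carrying an amine or a carboxylic acid would compare.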